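Aryl group exchange on the ring amine: compound 4 outlook

The source may hold more compounds than are shown below. What is called first, only, known or untested is meant among the compounds shown, and "the series" means these compounds.

Among the compounds with values here, compound 3 `CCCc1nc(-c2ccccc2)c(CNCCCN2CCN(c3cccc(C(F)(F)F)c3)CC2)o1` gives 51.6% in an assay on HEK293 cells for inhibition of Voltage-dependent T-type calcium channel subunit alpha-1G (Homo sapiens), read by fluorescence, tested at 10 uM (a higher number here means more inhibition at the concentration tested (going by the name of the read-out), a lower number less inhibition), the highest of the three numbers so far. Compound 1 `CCCc1nc(-c2ccccc2)c(CNCCCN2CCN(c3ccccc3OC)CC2)o1` gives 41% and compound 2 `CCCc1nc(-c2ccccc2)c(CNCCCN2CCN(c3ccccc3C(F)(F)F)CC2)o1` gives 45% in this assay. Of the three steps, a number 10.6 percentage points higher from compound 1 to compound 3 (beyond the scatter) is the only one beyond the scatter; a number 4 percentage points higher from compound 1 to compound 2 (within the scatter) and a number 6.6 percentage points higher from compound 2 to compound 3 (within the scatter) are within it. Compound 4 `CCCc1nc(-c2ccccc2)c(CNCCCN2CCN(c3ccc(OC)cc3)CC2)o1` brings the change (4-methoxyphenyl in place of 3-(trifluoromethyl)phenyl on an amine nitrogen in a ring). The step bearing most on it is a number 10.6 percentage points higher from compound 1 to compound 3 (beyond the scatter), which also swapped methoxy for trifluoromethyl; a number 6.6 percentage points higher from compound 2 to compound 3 (within the scatter) shows that ring position alone gave no step beyond the scatter. A modest downward step is therefore expected, roughly reversing the gain seen in a number 10.6 percentage points higher from compound 1 to compound 3 (beyond the scatter). Compound 4 is estimated at 44%, range 32% to 56%. This estimate implies an expected step of a number 7.6 percentage points lower from compound 3 to compound 4 (within the scatter).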

Compound 4, a percentage reported as inhibition, at one concentration (the size of the read-out at that concentration, not a potency): 42.1%
Compound 4: the middle estimate sits 1.9 percentage points above what was measured; low and high end bracket the measured number.
By their numbers in this assay, from the lowest: compounds 1, 4, 2 and 3 (each within the scatter of the next, the first and the last beyond it).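

At the amine nitrogen in the ring, 4-methoxyphenyl in place of 2-methoxyphenyl gives a number 1.1 percentage points higher from compound 1 to compound 4 (within the scatter), so moving methoxy between these two named aryl groups produces no readable step. The trifluoromethyl comparisons, a number 2.9 percentage points lower from compound 2 to compound 4 (within the scatter) and a number 9.5 percentage points lower from compound 3 to compound 4 (within the scatter), also stay within the scatter, so 4-methoxyphenyl separates from none of the other three aryl groups, although compound 1 and compound 3 do separate. No measured evidence explains these results.

Still open, as far as these compounds go, is how a phenyl group carrying a nitrile or a carboxylic acid would read on this ring nitrogen.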